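Nitro removal in the thiol series: compound 1 to compound 4

The source may hold more compounds than are shown below. What is called first, only, known or untested is meant among the compounds shown, and "the series" means these compounds.

Values in a functional assay on the whole organism with Mus musculus as the target; on this read-out lower numbers stand for an effect already at smaller amounts and higher numbers for an effect only at larger amounts of compound
- compound 1 `COc1cc2c(cc1OC)C(c1ccc([N+](=O)[O-])cc1)=NN=C(S)C2` gives 93.4 umol/kg
- compound 2 `COc1cc2c(cc1OC)C(c1ccc([N+](=O)[O-])cc1)=NNC(=O)C2` gives > 120 umol/kg
- compound 3 `COc1cc2c(cc1OC)C(c1ccc(N)cc1)=NN(C)C(=S)C2` gives 29.8 umol/kg

Of the two true numbers, compound 1 stands higher at 93.4 umol/kg. Compound 3 gives 29.8 umol/kg. The gap between these two compounds lies beyond the scatter. For compound 2, > 120 umol/kg is a limit, not a number.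

Compound 4 `COc1cc2c(cc1OC)C(c1ccccc1)=NN=C(S)C2` has hydrogen in place of nitro on an aromatic carbon, para to a large group (hydrogen in place of nitro on an aromatic carbon). Among the measured compounds shown here, no measured pair isolates this change. A small move towards lower numbers in this assay is expected, possibly within the scatter, with compound 3 at 29.8 umol/kg as the only lower reference. The expected change is a 1.2-fold lower number from compound 1 to compound 4 (0.10 log units; within the scatter). Compound 4 is estimated at 75 umol/kg, with an expected range from 30 umol/kg to 170 umol/kg.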

Compound 4, dose for half-maximal effect: 19.7 umol/kg
For compound 4 the middle estimate is 3.8-fold (0.58 log units) above the measured one; measured number outside the range, below it.
By their numbers in this assay, from the lowest: compounds 4 and 3 (each within the scatter of the next); then compound 1. At a limit, above all of these: compound 2.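

In this assay, hydrogen in place of nitro on an aromatic carbon, para to a large group, gives a 4.7-fold lower number from compound 1 to compound 4 (0.68 log units; beyond the scatter). This pair shows that the nitro group is not needed for an effect on the core of compound 1, and that its loss moves the number lower by more than the scatter. No measured property in the data bears on the reason for this step.

On these data alone, whether this position tolerates any group other than hydrogen stays open. A fluorine, a nitrile or a methoxy group at this carbon would test this.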